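Isopropyl to tert-butyl on a shared dimethoxy core

The source may hold more compounds than are shown below. What is called first, only, known or untested is meant among the compounds shown, and "the series" means these compounds.

Measured so far:
compound 1 `CCNC(=O)CC1CCc2cc(OC)c(OC)cc21`: 23.6%
compound 2 `COc1cc2c(cc1OC)C(CC(=O)NC(C)C)CC2`: 29.3%

In a functional assay on the whole organism (strain Swiss albino) for inhibition, with Mus musculus as the target, in the writhing test, with stated times of 60 min and 15 min, at a dose of 100 mg/kg by the oral route (a lower number here means less inhibition, a higher number more inhibition at the dose given (going by the name of the read-out)), compound 1 gives 23.6%, while compound 2 gives 29.3%. Among the compounds with values here, the single step between them, a number 5.7 percentage points higher from compound 1 to compound 2 (within the scatter), separates the two numbers by less than the usual scatter, so compound 2 holds the higher of the two numbers without standing apart from compound 1.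

Compound 3 `COc1cc2c(cc1OC)C(CC(=O)NC(C)(C)C)CC2` follows the same line one carbon further: methyl in place of hydrogen on a saturated chain carbon bound to an amide-type nitrogen and two saturated chain carbons, which reads as isopropylcarbamoyl to (tert-butyl)carbamoyl. Within the data shown here, the only measured step that bears on it is a number 5.7 percentage points higher from compound 1 to compound 2 (within the scatter), and it stayed within the scatter. Nothing here points to a larger effect from a second methyl at this place, so compound 3 is expected to move only within the scatter, a number 1.7 percentage points higher from compound 2 to compound 3 (within the scatter). The estimate for compound 3 in this assay is therefore 31%, with a range from 18% to 44%.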

Compound 3, a percentage reported as inhibition, in the whole organism at one dose (the size of the read-out at that dose, not a potency): 41.8%
The estimate for compound 3 lay 10.8 percentage points below the measured number; the measured number falls inside the stated range.
By their numbers in this assay, from the lowest: compounds 1 and 2 (each within the scatter of the next); then compound 3.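

In this assay, within the data shown here, the change of isopropyl to tert-butyl gives a number 12.5 percentage points higher from compound 2 to compound 3 (beyond the scatter) whereas the earlier methyl step gave only a number 5.7 percentage points higher from compound 1 to compound 2 (within the scatter) and so this is the first change on the amide-type nitrogen's substituent to clear the scatter. Read from the other end of the series, tert-butyl in place of ethyl gives a number 18.2 percentage points higher from compound 1 to compound 3 (beyond the scatter) and compound 3 therefore stands apart from both compound 1 and compound 2, with the highest number of the three at this single dose. Nothing measured here accounts for this rise.

Still open, from the compounds shown here alone, is what a different substituent on the amide-type nitrogen would give, such as a cyclohexyl ring or a longer chain like n-butyl, or the bare amide with only hydrogen there. These single-dose numbers also leave open how potency runs across the three compounds.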